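The source may hold more compounds than are shown below. What is called first, only, known or untested is meant among the compounds shown, and "the series" means these compounds.

Working notes on the series

The series is built from two diaryl dienone cores. Compound 1 `O=C(/C=C/c1cccc(O)c1)CC(=O)/C=C/c1cccc(O)c1O` and compound 2 `O=C(/C=C/c1cc(O)ccc1O)CC(=O)/C=C/c1cccc(O)c1O` share the first core; compound 3 `O=C(/C=C/c1cccc(O)c1)/C=C/c1ccc(O)c(O)c1` and the still unmeasured compound 4 `O=C(/C=C/c1ccc(O)c(O)c1)/C=C/c1cc(O)ccc1O` share the second. The difference between the two cores is not broken down here.

In a functional assay, with a stated time of 30 min (a lower number here means a stronger inhibitor, a higher number a weaker inhibitor), compound 1 gives 29000 nM, and compound 2 gives 27000 nM. The change between them is hydroxy in place of hydrogen on an aromatic carbon, and the step it made, a 1.1-fold lower number from compound 1 to compound 2 (0.03 log units; within the scatter), is not distinguishable from repeat variation. Compound 3 gives 71000 nM, the highest number of the three measured, beyond the scatter relative to both compound 1 and compound 2.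

The change from compound 3 to compound 4 is hydroxy in place of hydrogen on an aromatic carbon. Its place reads word for word as the place of the change from compound 1 to compound 2, so it is the same change, seen here for the second time among the compounds shown. Since that change left the number of compound 1 essentially where it was, the expectation for compound 4 is that its number stays close to that of compound 3, with a step of a 1.1-fold lower number from compound 3 to compound 4 (0.04 log units; within the scatter) that is estimated to sit within the scatter. Compound 4 is therefore expected to give about 65000 nM, plausibly between 30000 nM and 150000 nM, in this assay, because compound 3 gives 71000 nM and the earlier step of a 1.1-fold lower number from compound 1 to compound 2 (0.03 log units; within the scatter) was small.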

Compound 4, half-maximal inhibitory concentration: 25000 nM
Estimate against measurement, compound 4: 2.6-fold (0.41 log units) above; the measured number lies below the stated range.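

In this assay, adding a hydroxy group, ortho to a large group and para to a hydroxy group, gives a 2.8-fold lower number from compound 3 to compound 4 (0.45 log units; beyond the scatter), a modest step that can be read as a real lowering of the number on this core. Set beside the step on the other core, this result does not separate the two cores, even though only one step lies beyond the scatter taken alone: the same change on two cores in this assay, a 1.1-fold lower number (0.03 log units; within the scatter) from compound 1 to compound 2 and a 2.8-fold lower number (0.45 log units; beyond the scatter) from compound 3 to compound 4, 2.6-fold (0.42 log units) apart, within the scatter of two such steps. This shows that the change did not raise the number on either core and that the size of its effect may be similar on both, but it does not show that the effect carries over unchanged or that it depends on the core, and two pairs are a thin basis for either reading.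

The compounds shown compare only hydrogen and hydroxy at this place, and whether a methoxy group, a fluorine atom or an amine there would move the number in the same way stays open on both cores. Also open, going by these compounds, is whether the step would hold on any further core, and how the two cores compare with each other when nothing else differs.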